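Working notes on an aryl ether replacement

A few compounds are considered here, and "the series" means these few. Any claim that something is new, unique, unknown or untested is made for them only; others in the source may bear on it.

Measured compounds:
- compound 1 `COc1cccc(Oc2ccc3cc(NC(=O)c4ccc(OC(C)=O)c(CC=C(C)C)c4)c(=O)oc3c2C)c1`: in a functional assay on MCF7 cells (Homo sapiens) for antiproliferative activity (on this read-out higher numbers stand for weaker inhibition and lower numbers for stronger inhibition), compound 1 gives 15700 nM
- compound 2 `CC(=O)Oc1ccc(C(=O)Nc2cc3ccc(Oc4ccc(C(C)(C)C)cc4)c(C)c3oc2=O)cc1CC=C(C)C`: in this assay compound 2 gives 75000 nM
- compound 3 `COc1cccc(Oc2ccc3cc(NC(=O)c4ccc(OC)c(-c5cccc(OC)c5)c4)c(=O)oc3c2C)c1`: in this assay compound 3 gives > 100000 nM, which is a limit of the assay and not a number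

Compound 1 and compound 2 share a core and differ by 4-(tert-butyl)phenyl in place of 3-methoxyphenyl on an oxygen on an aromatic ring. That change produced a 4.8-fold higher number from compound 1 to compound 2 (0.68 log units; beyond the scatter). Compound 3 carries a different amide part; how the core of compound 3 differs from the core of compound 1 is not broken down here. The value of compound 3 sits at the limit of > 100000 nM in this assay, at which 1 of the 3 values shown sits, so only a limit is known for it.

Compound 4 `COc1cccc(-c2cc(C(=O)Nc3cc4ccc(Oc5ccc(C(C)(C)C)cc5)c(C)c4oc3=O)ccc2OC)c1` is not yet measured. It differs from compound 3 by 4-(tert-butyl)phenyl in place of 3-methoxyphenyl on an oxygen on an aromatic ring, the same change as from compound 1 to compound 2, at a place described in the same words. The measured step of that change was a loss, and it was made on a compound that already gave a number rather than a limit. Compound 3 starts at a limit, so compound 4 is expected to stay at or beyond that limit, and the step expected from compound 3 to compound 4 is a step that the limit leaves unreadable from compound 3 to compound 4, resting on the loss seen in a 4.8-fold higher number from compound 1 to compound 2 (0.68 log units; beyond the scatter). Compound 4 is therefore estimated at 300000 nM in this assay, with an expected range from 100000 nM to 1000000 nM, most likely reported only as a limit.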

Compound 4, half-maximal inhibitory concentration: > 100000 nM
Compound 4: a limit, no number; the forecaster's own chance of this, stated with the estimate: 90%; the middle value does not contradict the limit.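

In this assay compound 4 gives > 100000 nM, which is a limit of the assay and not a number. Compound 3 also stands at a limit, so no step from compound 3 to compound 4 can be read: the limit of > 100000 nM in this assay, at which 2 of the 4 values shown sit.

The compounds shown leave open whether 4-(tert-butyl)phenyl in place of 3-methoxyphenyl changes the read-out with the amide part of compound 3 as it does with the amide part of compound 1.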